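Aryl swap on the dihydropyridine-type core of compound 1

This account rests on a few compounds, and the source may have more. Where it says the series, first, only, none or still open, it means among the compounds named here.

The series rests on a shared core carrying two methyl groups, two methoxycarbonyl groups and an aryl group on a saturated ring carbon. Compound 1 `COC(=O)C1=C(C)N=C(C)/C(=C(\O)OC)C1c1ccccc1I` bears a 2-iodophenyl group there; in a functional assay (muscle tissue) with Cavia porcellus as the target (on this read-out higher numbers stand for an effect only at larger amounts of compound and lower numbers for an effect already at smaller amounts), compound 1 gives 46.8 nM. Compound 2 `COC(=O)C1=C(C)N=C(C)/C(=C(\O)OC)C1c1cc([N+](=O)[O-])ccc1Cl` carries a 5-nitro-2-chlorophenyl group in the same place, and in this assay compound 2 gives 30.2 nM. Compound 1 shows the higher of the two numbers, but the gap to compound 2 lies within the scatter, so the two values cannot be told apart on these data.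

Compound 3 `COC(=O)C1=C(C)N=C(C)/C(=C(\O)OC)C1c1ccc(Br)cc1` is the next compound to be measured in this assay. Against compound 1 the change is 4-bromophenyl in place of 2-iodophenyl on a saturated ring carbon. Going by the values given here, no measured pair tells how this swap acts, so the expectation rests on the two values alone. For compound 3 the step of a 3.2-fold higher number from compound 1 to compound 3 (0.51 log units; beyond the scatter) is expected to run toward a higher number, beyond the scatter, with wide uncertainty. Compound 3 is estimated at 150 nM, with a range from 40 nM to 600 nM.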

Compound 3, half-maximal effective concentration: 540 nM
For compound 3 the middle estimate is 3.6-fold (0.56 log units) below the measured one; the range from low to high includes it.
By their numbers in this assay, from the lowest: compounds 2 and 1 (each within the scatter of the next); then compound 3.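

Notes on the aryl position: in this assay, the saturated ring carbon of the shared core is sensitive to the choice of halogen-bearing phenyl group, since 4-bromophenyl in place of 2-iodophenyl gives a 12-fold higher number from compound 1 to compound 3 (1.06 log units; beyond the scatter). This large step comes although the leaving and entering groups match in heavy-atom count, in their carbon-only aromatic ring and in having no hydrogen-bond donors or acceptors, so those counted features do not separate the two groups, while the halogen and its place on the phenyl ring differ together. Nothing available here bears on the reason for the step.

Going by these compounds alone, the single swap leaves open whether the step follows the halogen or its place on the phenyl ring; 2-bromophenyl and 4-iodophenyl would separate these two changes within the same core. On these data alone, it also remains open how this position responds to an aryl group without halogen, such as plain phenyl, or to one carrying an amine or a carboxylic acid.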